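Fluoro in place of ethyl: expecting compound 4

This account rests on a few compounds, and the source may have more. Where it says the series, first, only, none or still open, it means among the compounds named here.

Measured so far:
compound 1, `COc1ccc(SCc2ccc(C(=O)Nc3ccccc3N)cc2)cc1`: 1640 nM
compound 2, `Cc1cc(C)cc(SCc2ccc(C(=O)Nc3ccccc3N)cc2)c1`: 2490 nM
compound 3, `CCc1ccc(SCc2ccc(C(=O)Nc3ccccc3N)cc2)cc1`: 1740 nM

These three share a core and differ only in the group attached to the sulfur, and in a functional assay on HCT-116 cells (Homo sapiens) for antiproliferative activity, read by CCK-8 assay, with a stated time of 72 h (a higher number here means a weaker inhibitor, a lower number a stronger inhibitor), they sit close together. Compound 3 gives 1740 nM, the second highest of the three numbers; the step of a 1.1-fold higher number from compound 1 to compound 3 (0.03 log units; within the scatter) and the step of a 1.4-fold lower number from compound 2 to compound 3 (0.16 log units; within the scatter) both stay within the scatter. Compound 4, `Nc1ccccc1NC(=O)c1ccc(CSc2ccc(F)cc2)cc1`, carries one change relative to compound 3: fluoro in place of ethyl on an aromatic carbon. Going by the values given here, no measured step swaps ethyl for fluoro directly, but the two steps just given show that exchanging the group on the sulfur among three variants moved nothing beyond the scatter. A similar outcome is therefore expected here, with a 1.1-fold higher number from compound 3 to compound 4 (0.04 log units; within the scatter) predicted to stay within the scatter. Compound 4 is estimated at 1900 nM, within a range from 900 nM to 4000 nM.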

Compound 4, half-maximal inhibitory concentration: 4010 nM
Compound 4: middle estimate off by 2.1-fold (0.32 log units), on the low side, outside the stated range (above it).
By their numbers in this assay, from the lowest: compounds 1, 3, 2 and 4 (each within the scatter of the next, the first and the last beyond it).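

On the aromatic carbon of the ring carried by the sulfur, exchanging the group can move the result beyond the scatter in this assay: fluoro in place of ethyl gives (a 2.3-fold higher number from compound 3 to compound 4 (0.36 log units; beyond the scatter)) and fluoro in place of methoxy gives (a 2.4-fold higher number from compound 1 to compound 4 (0.39 log units; beyond the scatter)). The 4-fluorophenyl group in place of 3,5-dimethylphenyl gives a step still within the scatter (a 1.6-fold higher number from compound 2 to compound 4 (0.21 log units; within the scatter)), so these modest shifts do not separate compound 4 from every other compound. Nothing available explains the rise with fluoro. From the compounds shown here alone, whether chloro or bromo at this place would resemble fluoro remains open, as does the result with an amine or a carboxylic acid there.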